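A tert-Butyl Swap on a Cytotoxicity Screen

The compounds below may be only part of what the source reports. "The series", "measured", "known", "first", "only" and "open" are said of these compounds alone.

Compound 1 `CC(C)n1nc(-c2cc(-c3ccccc3)on2)c2c(N)ncnc21` has been run in an ADME assay on BaF3 cells (Mus musculus) for cytotoxicity, read by MTT assay, with a stated time of 48 h; a higher number here means a weaker inhibitor of growth, a lower number a stronger inhibitor of growth. In this assay compound 1 gives > 10000 nM, which is a limit of the assay rather than a measured number. Two further compounds, differing from compound 1 elsewhere in their structures, have been run in the same way. Compound 2 `CC(C)n1nc(/C=N/OCc2ccccc2)c2c(N)ncnc21` gives in this assay > 10000 nM, again a limit. Compound 3 `CCCCCCCn1nc(-c2cc(C3CC3)on2)c2c(N)ncnc21` gives in this assay > 10000 nM, also a limit. Compound 1 therefore stands exactly where every value shown stands: the limit of > 10000 nM in this assay, at which 3 of the 3 values shown sit. No two of these compounds differ in only one place, so no single measured step connects them.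

Compound 4 `CC(C)n1nc(-c2cc(C(C)(C)C)on2)c2c(N)ncnc21` is not yet measured. It differs from compound 1 in one place: tert-butyl in place of phenyl on an aromatic carbon. Going by the values given here, because all three known values sit at the limit (the limit of > 10000 nM in this assay, at which 3 of the 3 values shown sit), there is no measured step of any size to draw on, and no direction of change is expected beyond the scatter. The expected step for this assay is a step that the limit leaves unreadable from compound 1 to compound 4, that is, no movement beyond the scatter. Compound 4 is estimated at 15000 nM, with a range from 4000 nM to 60000 nM, and most likely the assay will again report only a limit.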

Compound 4, concentration for 50% growth inhibition: > 10000 nM
Compound 4 ended at the assay's limit; the forecaster's own chance of this, stated with the estimate: 80%; the middle value lies beyond the limit too.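

The step from compound 1 to compound 4 cannot be read, because both results are limits of the assay and not numbers: the limit of > 10000 nM in this assay, at which 4 of the 4 values shown sit.

The compounds shown leave open how strongly any of them inhibits growth in this assay, and so whether tert-butyl in place of phenyl changes the result at all.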